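The source may hold more compounds than are shown below. What is called first, only, known or untested is meant among the compounds shown, and "the series" means these compounds.

Series notes. In a functional assay on HCT-116 cells (Homo sapiens) for inhibition, read by CCK-8 assay, with a stated time of 48 h (a higher number here means a weaker inhibitor, a lower number a stronger inhibitor), compound 1 (`COc1cc(N(Cc2ccc(Br)cc2)C(=O)CSC(=S)N2CCN(C(=O)OC(C)(C)C)CC2)cc(OC)c1OC`) gives 11400 nM as its half-maximal inhibitory concentration. For the measured compounds named here, compound 2 (`COc1cc(NC(=O)CSC(=S)N2CCN(C(=O)OC(C)(C)C)CC2)c(Cc2ccccc2)c(OC)c1OC`) gives 16000 nM in the same read-out, so compound 1 stands within the usual scatter of the only other number available. Compound 3 (`COc1ccc(CN(C(=O)CSC(=S)N2CCN(C(=O)OC(C)(C)C)CC2)c2cc(OC)c(OC)c(OC)c2)cc1N=[N+]=[N-]`) is still to be measured in this assay. It departs from compound 1 in one place (3-azido-4-methoxyphenyl in place of 4-bromophenyl on a saturated chain carbon bound to an amide-type nitrogen): 3-azido-4-methoxyphenyl in place of 4-bromophenyl on a saturated chain carbon bound to an amide-type nitrogen. Going by the values given here, no measured pair differs in a single place, so the size of such a change has no direct precedent here. Resting on compound 1 at 11400 nM as the anchor, no shift beyond the scatter is expected, in either direction. The estimated step (a 1.1-fold higher number from compound 1 to compound 3 (0.02 log units; within the scatter)) is accordingly small. For compound 3 the estimate is 12000 nM with an expected range of 4000 nM to 35000 nM in this read-out.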

Compound 3, half-maximal inhibitory concentration: 780 nM
The estimate for compound 3 lay 15-fold (1.19 log units) above the measured number; the measured number lies below the stated range.
By their numbers in this assay, from the lowest: compound 3; then compounds 1 and 2 (each within the scatter of the next).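

In this assay, the group on a saturated chain carbon bound to an amide-type nitrogen proves sensitive to substitution: 3-azido-4-methoxyphenyl in place of 4-bromophenyl gives a 15-fold lower number from compound 1 to compound 3 (1.16 log units; beyond the scatter) and lies beyond the scatter. For the compounds shown here, this is the first change in a single place that can be read, and it shows that this position can carry a large shift in the number, in the direction of a stronger inhibitor. No measurement on hand accounts for the size of the step.

The change removes the bromine and adds both the azido and methoxy groups, so the compounds shown do not separate the share of each. On these data alone, whether an amine or a nitrile in place of the azido group would keep the step remains open.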